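Swapping the Halogenated Aryl Group in a Fused Bicyclic Core

A few compounds are considered here, and "the series" means these few. Any claim that something is new, unique, unknown or untested is made for them only; others in the source may bear on it.

Measured compounds:
Compound 1, `CC(c1ccc(-c2ccccc2)c(F)c1)c1nnc2n1N=C(c1ccc(Cl)cc1Cl)CS2`, gives 6600 nM.
Compound 2, `CC(C)Cc1ccc(C(C)c2nnc3n2N=C(c2ccc(OC(F)(F)F)cc2)CS3)cc1`, gives 9100 nM.
Compound 3, `CC(c1ccc(-c2ccccc2)c(F)c1)c1n[nH]c(=S)n1N`, is reported as "not active" (no number reported), with no number.

In a functional assay on Mahlavu cells (Homo sapiens) for inhibition, read by sulforhodamine B assay, with a stated time of 72 h (on this read-out higher numbers stand for weaker inhibition and lower numbers for stronger inhibition), compound 1 and compound 2 lie within the usual scatter of each other, so neither can be set above the other. Compound 3 carries no number in this assay. Within the data shown here, compound 4, `CC(c1ccc(-c2ccccc2)c(F)c1)c1nnc2n1N=C(c1ccc(Br)cc1)CS2`, keeps the core of compound 1 and changes only one group: 4-bromophenyl in place of 2,4-dichlorophenyl on a carbon with a double bond to nitrogen. Among the measured compounds shown here, no measured pair shows how this kind of swap moves the read-out, so the expectation rests on compound 1 alone. The step from compound 1 to compound 4 is expected to stay within the scatter, with a slight lean toward a weaker value, a 1.2-fold higher number from compound 1 to compound 4 (0.08 log units; within the scatter). For compound 4 the estimate is 8000 nM, within a range of 3500 nM to 18000 nM.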

Compound 4, half-maximal inhibitory concentration: 6200 nM
The estimate for compound 4 lay 1.3-fold (0.11 log units) above the measured number; the range from low to high includes it.
By their numbers in this assay, from the lowest: compounds 4, 1 and 2 (each within the scatter of the next).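

In this assay the change to 4-bromophenyl in place of 2,4-dichlorophenyl on a carbon with a double bond to nitrogen gives a 1.1-fold lower number from compound 1 to compound 4 (0.03 log units; within the scatter) and so stays within the usual scatter. At this position on the shared core, the two chlorine atoms can therefore give way to one bromine with no change that can be told from scatter. No measurement at hand bears on why the number holds here.

Both groups compared are halogenated phenyl rings. On these data alone, how an amine or a carboxylic acid on that ring would read, or a plain alkyl chain in its place, remains open.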